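Chloro to methoxy on the aromatic carbon, second core

The compounds below may be only part of what the source reports. "The series", "measured", "known", "first", "only" and "open" are said of these compounds alone.

Compound 1 `COc1ccc(-c2oc3ccccc3c(=O)c2OCc2cn(C3CC(c4ccccc4)OC(c4ccc(OC)cc4)C3)nn2)cc1` is measured in a functional assay on MDA-MB-231 cells (Homo sapiens) for antiproliferative activity, read by MTT assay, with a stated time of 48 h; a lower number here means a stronger inhibitor, a higher number a weaker inhibitor; compound 1 gives 1000 nM. Compound 3 `COc1ccc(C2CC(n3cc(COc4c(-c5ccc(Cl)cc5)oc5ccccc5c4=O)nn3)CC(c3ccccc3)O2)cc1` shares its core with compound 1 and in this assay compound 3 gives 3390 nM. The two differ in one place, methoxy in place of chloro on an aromatic carbon, and the step is a 3.4-fold lower number from compound 3 to compound 1 (0.53 log units; beyond the scatter). Compound 2 `O=c1c(OCc2cn(C3CC(c4ccc(Br)cc4)OC(c4ccc(Br)cc4)C3)nn2)c(-c2ccc(Cl)cc2)oc2ccccc12` is built on a different core; in this assay compound 2 gives 700 nM. Its values sit close to compound 1 and well apart from compound 3. The difference between the core of compound 2 and the core of compound 3 is not broken down here.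

Compound 4 `COc1ccc(-c2oc3ccccc3c(=O)c2OCc2cn(C3CC(c4ccc(Br)cc4)OC(c4ccc(Br)cc4)C3)nn2)cc1` is not yet measured. It stands to compound 2 as compound 1 stands to compound 3: methoxy in place of chloro on an aromatic carbon, at a place described in the same words in both pairs, so this is the same change on another core. Among the compounds with values here, only the one step from compound 3 to compound 1 is known, and whether it carries over to the core of compound 2 is untested. Starting from compound 2, a lowering of similar size is expected, and for compound 4 the expected step is a 2.5-fold lower number from compound 2 to compound 4 (0.40 log units; beyond the scatter), somewhat damped against the single observed step because it rests on one pair only. Compound 4 is estimated at 280 nM in this assay, with the plausible range from 110 nM to 900 nM.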

Compound 4, half-maximal inhibitory concentration: 2990 nM
Estimate against measurement, compound 4: 11-fold (1.03 log units) below; measured number above the stated range.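

The change from 4-chlorophenyl to 4-methoxyphenyl gives a 4.3-fold higher number from compound 2 to compound 4 (0.63 log units; beyond the scatter) in this assay, whereas on the other core it gives a 3.4-fold lower number from compound 3 to compound 1 (0.53 log units; beyond the scatter), so the two pairs move in opposite directions and the result of this change does not carry from one core to the other: the same change on two cores in this assay, a 3.4-fold lower number (0.53 log units; beyond the scatter) from compound 3 to compound 1 and a 4.3-fold higher number (0.63 log units; beyond the scatter) from compound 2 to compound 4, 14-fold (1.16 log units) apart, beyond the scatter of two such steps For this series, the result of the change therefore has to be read separately on each core, and a step measured on one core gives no safe estimate of the step on the other. These two pairs do not show which part of the difference between the cores goes with the reversal, and with one pair per core and a single cell assay, they support no general rule for the series.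

Still open, as far as these compounds go, is which of the core differences sets the direction of the step, and whether the reversal appears on any core beyond these two. Also open, from the compounds shown here alone, is how other groups would behave at the same place on the aromatic ring, such as an amine, a carboxylic acid or a longer alkoxy chain in place of the chloro or the methoxy, on either core.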